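Removing the trifluoromethyl from compound 3: an unmeasured step

The source may hold more compounds than are shown below. What is called first, only, known or untested is meant among the compounds shown, and "the series" means these compounds.

Three compounds share one core and differ only in the aryl group on the amine nitrogen in a ring. Compound 1 `Cc1nc(-c2ccccc2)c(C(=O)N2CCN(c3cccc(C)c3C)CC2)o1` gives 35 nM in a functional assay on HL-60 cells (Homo sapiens) for inhibition, read by MTT assay, with a stated time of 72 h; on this read-out lower numbers stand for stronger inhibition and higher numbers for weaker inhibition. Compound 2 `Cc1nc(-c2ccccc2)c(C(=O)N2CCN(c3ccccc3Cl)CC2)o1` gives 124 nM in this assay, and compound 3 `Cc1nc(-c2ccccc2)c(C(=O)N2CCN(c3ccccc3C(F)(F)F)CC2)o1` gives 120 nM. Compound 3 thus stands second highest of the three numbers, with compound 2 nearest, the gap a 1.0-fold lower number from compound 2 to compound 3 (0.01 log units; within the scatter), and compound 1 furthest, the gap a 3.4-fold higher number from compound 1 to compound 3 (0.54 log units; beyond the scatter).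

Compound 4 `Cc1nc(-c2ccccc2)c(C(=O)N2CCN(c3ccccc3)CC2)o1` is the next step: hydrogen in place of trifluoromethyl on an aromatic carbon. For the measured compounds named here, no measured step removes a substituent outright. The steps of a 3.5-fold higher number from compound 1 to compound 2 (0.55 log units; beyond the scatter) and a 3.4-fold higher number from compound 1 to compound 3 (0.54 log units; beyond the scatter) show that swapping 2,3-dimethylphenyl for a singly substituted ring raised the number modestly, while a 1.0-fold lower number from compound 2 to compound 3 (0.01 log units; within the scatter) shows chloro and trifluoromethyl giving the same result. Taking the substituent away entirely is untested, so the direction is uncertain. Compound 4 is therefore expected to give 150 nM, a step of a 1.3-fold higher number from compound 3 to compound 4 (0.10 log units; within the scatter), within a range of 50 nM to 500 nM.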

Compound 4, half-maximal inhibitory concentration: 39.1 nM
Compound 4: middle estimate off by 3.8-fold (0.58 log units), on the high side; measured number below the stated range.
By their numbers in this assay, from the lowest: compounds 1 and 4 (each within the scatter of the next); then compounds 3 and 2 (each within the scatter of the next).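

In this assay the plain phenyl ring shows that chloro and trifluoromethyl, which gave matching numbers, are both worse here than no substituent at all: hydrogen in place of trifluoromethyl gives a 3.1-fold lower number from compound 3 to compound 4 (0.49 log units; beyond the scatter) and hydrogen in place of chloro gives a 3.2-fold lower number from compound 2 to compound 4 (0.50 log units; beyond the scatter) on this aromatic carbon. Phenyl in place of 2,3-dimethylphenyl gives a 1.1-fold higher number from compound 1 to compound 4 (0.05 log units; within the scatter) and so leaves the number unchanged, which ties the earlier rise to the chloro and trifluoromethyl rings and not to the loss of the two methyl groups. Nothing measured here explains why these two groups raise the number.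

As far as these compounds go, whether a single methyl, a methoxy or an amine on this same carbon would also raise the number remains open. So does whether chloro or trifluoromethyl would have the same effect elsewhere on the ring.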